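A Dimethylamino Swap Among Compounds Read Only as Limits

The compounds below may be only part of what the source reports. "The series", "measured", "known", "first", "only" and "open" are said of these compounds alone.

Three compounds sharing one core have been examined in an ADME assay on Akata cells (Homo sapiens) for cytotoxicity, with a stated time of 7 days; a higher number here means that more compound is tolerated, a lower number that less compound is tolerated: compound 1 `CC(C)CSc1nc(N)nc2c1ncn2/C=C1/CC1(CO)CO` with isobutylsulfanyl, compound 2 `CCOc1nc(N)nc2c1ncn2/C=C1/CC1(CO)CO` with ethoxy, and compound 3 `COCCOc1nc(N)nc2c1ncn2/C=C1/CC1(CO)CO` with 2-methoxyethoxy on the same aromatic carbon. Compound 1 gives > 20000 nM, which is a limit and not a number. Compound 2 gives > 20000 nM, likewise a limit. Compound 3 gives > 20000 nM, also a limit, so its place among the three cannot be ranked.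

The next compound is compound 4 `CN(C)c1nc(N)nc2c1ncn2/C=C1/CC1(CO)CO`, which has dimethylamino in place of 2-methoxyethoxy on an aromatic carbon next to the ring nitrogen, (dimethylamino in place of 2-methoxyethoxy on an aromatic carbon). Two measured changes at this carbon bear on it: a step that the two limits leave unreadable from compound 1 to compound 2 and a step that the two limits leave unreadable from compound 1 to compound 3. The change within the side chain, a step that the two limits leave unreadable from compound 2 to compound 3, is also relevant. None of the three has a readable size, and the whole record amounts to the limit of > 20000 nM in this assay, at which 3 of the 3 values shown sit.

For the measured compounds named here, no measured step therefore points to a direction or a size, and no shift beyond the scatter is expected in this assay. The expected change is a number no higher from compound 3 to compound 4 (the limit leaves the size open). Compound 4 is estimated at 20000 nM, with an expected range from 7000 nM to 40000 nM. It may well be reported as a limit again.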

Compound 4, half-maximal cytotoxic concentration: > 24000 nM
Compound 4: no number, only a limit (the forecaster's own chance of this, stated with the estimate: 75%); at least 1.2-fold (0.07 log units) between middle value and limit.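

In this assay compound 4 gives > 24000 nM, which is a limit and not a number, so its steps from compound 1, compound 2 and compound 3 cannot be read. The compounds shown leave open whether isobutylsulfanyl, ethoxy, 2-methoxyethoxy and dimethylamino differ at all on the shared core, and at what concentration any of the four becomes cytotoxic.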